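The source may hold more compounds than are shown below. What is called first, only, known or untested is meant among the compounds shown, and "the series" means these compounds.

Among the measured compounds shown here, in an ADME assay (liver) for metabolic stability, with Liver microsome (Rattus norvegicus) as the target, using microsomes and NADPH, with a stated time of 30 min, tested at 1 uM (a lower number here means slower removal, a higher number faster removal of the compound), compound 1 `Nc1ccc(S(=O)(=O)N2CCN(c3ncc(C(O)(C(F)(F)F)C(F)(F)F)cc3-c3ccccc3O)CC2)cn1` gives 125 mL.min-1.g-1, while compound 2 `Nc1ccc(S(=O)(=O)N2CCN(c3ncc(C(O)(C(F)(F)F)C(F)(F)F)cc3-c3ccncc3)CC2)cn1` gives 31 mL.min-1.g-1, the lower of the two numbers measured so far. For the measured compounds named here, the only measured step is a 4.0-fold lower number from compound 1 to compound 2 (0.61 log units; beyond the scatter), with pyridin-4-yl in place of 2-hydroxyphenyl on an aromatic carbon. Compound 3 `COc1ccc(-c2cc(C(O)(C(F)(F)F)C(F)(F)F)cnc2N2CCN(S(=O)(=O)c3ccc(N)nc3)CC2)cn1` differs from compound 2 at that same place: 6-methoxypyridin-3-yl in place of pyridin-4-yl on an aromatic carbon. Here 6-methoxypyridin-3-yl stands in place of pyridin-4-yl, ortho to a large group and two atoms from the ring nitrogen. Going by the values given here, the measured step shows that a change at this place can exceed the scatter, but no measured compound carries 6-methoxypyridin-3-yl, so it offers only a loose guide. A modest rise, smaller than that step, is therefore expected in this assay. The expected change is a 2.3-fold higher number from compound 2 to compound 3 (0.35 log units; beyond the scatter). For compound 3, the estimated value is 70 mL.min-1.g-1, with an expected range of 30 mL.min-1.g-1 to 150 mL.min-1.g-1.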

Compound 3, intrinsic clearance in microsomes: 265 mL.min-1.g-1
Beside the measured number, compound 3's estimate is 3.8-fold (0.58 log units) below it; measured number above the stated range.
By their numbers in this assay, from the lowest: compound 2; then compound 1; then compound 3.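

In this assay, swapping a pyridine ring for a pyridine ring is enough to move the number strongly at this place: both groups are six-membered aromatic rings with one hetero atom, yet the change to 6-methoxypyridin-3-yl gives an 8.5-fold higher number from compound 2 to compound 3 (0.93 log units; beyond the scatter). The earlier step might have suggested that a pyridine ring in place of 2-hydroxyphenyl lowers the number, but compound 3 goes against this, with a 2.1-fold higher number from compound 1 to compound 3 (0.33 log units; beyond the scatter), so ring type alone does not set the outcome among these three compounds. Nothing at hand explains why the methoxy-bearing ring gives the highest number of the three. The compounds shown leave open whether the methoxy group or the different attachment of the pyridine ring carries the step, a question that plain pyridin-3-yl would separate. As far as these compounds go, how an amine or a carboxylic acid on that ring would behave also remains open.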